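A few compounds are considered here, and "the series" means these few. Any claim that something is new, unique, unknown or untested is made for them only; others in the source may bear on it.

Measured so far in a functional assay on KYSE-70 cells for antiproliferative activity against KYSE-70 cell line (Homo sapiens), read by MTT assay, with a stated time of 72 h; on this read-out lower numbers stand for stronger inhibition and higher numbers for weaker inhibition:

- Compound 1 `O=C(Nc1cccc(F)c1)c1cc(=O)[nH]c2cc(Br)ccc12`: 8900 nM
- Compound 2 `COc1cccc(NC(=O)c2cc(=O)[nH]c3cc(Br)ccc23)c1`: > 20000 nM (a limit, not a number)
- Compound 3 `O=C(Nc1cccc(OC(F)(F)F)c1)c1cc(=O)[nH]c2cc(Br)ccc12`: > 20000 nM (a limit, not a number)

Compound 1 is the only one of the three with an actual number, while the other two sit at the limit of > 20000 nM in this assay, at which 2 of the 3 values shown sit. Compound 4 `O=C(Nc1cccc(F)c1)c1cc(=O)[nH]c2cc(-c3ccsc3)ccc12` differs from compound 1 in one place, with thiophen-3-yl in place of bromo on an aromatic carbon.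

Two measured steps replace the fluoro group of compound 1: an at least 2.2-fold higher number from compound 1 to compound 2 (0.35 log units; beyond the scatter) and an at least 2.2-fold higher number from compound 1 to compound 3 (0.35 log units; beyond the scatter). Both are beyond the scatter and point towards weaker inhibition, so a single swap can cost activity in this series. The third, a step that the two limits leave unreadable from compound 2 to compound 3, tells nothing about size. None of them touches the bromo position, so they give no direction for this change, and no step beyond the scatter is the plainest expectation, with wide uncertainty and a real chance of a limit. The expected change is a 1.1-fold lower number from compound 1 to compound 4 (0.05 log units; within the scatter). The estimate for compound 4 is 8000 nM, with an expected range from 2500 nM to 20000 nM.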

Compound 4, half-maximal inhibitory concentration: 5100 nM
For compound 4 the middle estimate is 1.6-fold (0.20 log units) above the measured one, and the stated range covers the measured number.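

Among the compounds shown here, this is the first step that touches the bromo position rather than the fluoro group, and in this assay it gives a 1.7-fold lower number from compound 1 to compound 4 (0.24 log units; within the scatter). So thiophen-3-yl, with 5 heavy atoms against the single bromine atom, can stand at this position without a loss of activity beyond the scatter, though the result cannot be called a gain either. Compound 4 also gives a real number, whereas both swaps of the fluoro group ended at a limit, which is not a number: the limit of > 20000 nM in this assay, at which 2 of the 4 values shown sit.

Only one replacement at this position is shown, so it stays open how an amine, a carboxylic acid or a longer chain would fare there. Going by these compounds, it is also open whether thiophen-3-yl would give a real number alongside the methoxy group of compound 2 or the trifluoromethoxy group of compound 3.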